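The source may report more compounds than this note shows. Statements on the series, on what has been measured and on what is new or still open speak of the compounds shown alone.

Among the three compounds measured in an in vivo ADME assay on the whole organism (strain Mongrel) for metabolic stability, with Canis familiaris (Canis lupus familiaris) as the target (on this read-out lower numbers stand for a shorter-lived compound and higher numbers for a longer-lived compound), compound 1 `COc1ncc(C(=O)NC2(C(=O)N[C@H](C)c3ccc(-n4nc(Cl)c5ccccc54)cc3F)CC2)s1` gives 8.3 h, and it is separated beyond the scatter only from compound 3; its number and that of compound 2 cannot be told apart. Compound 2 `C[C@@H](NC(=O)C1(NC(=O)c2cncc(Cl)c2)CC1)c1ccc(-n2nc(Cl)c3ccccc32)cc1F` carries a 5-chloropyridin-3-yl on the carbonyl carbon, and in this assay compound 2 gives 6 h, so that a 1.4-fold lower number from compound 1 to compound 2 (0.14 log units; within the scatter). Compound 3 `COc1cncc(C(=O)NC2(C(=O)N[C@H](C)c3ccc(-n4nc(Cl)c5ccccc54)cc3F)CC2)c1` carries a 5-methoxypyridin-3-yl in the same place, and in this assay compound 3 gives 2.3 h; here a 3.6-fold lower number from compound 1 to compound 3 (0.56 log units; beyond the scatter), and a 2.6-fold lower number from compound 2 to compound 3 (0.42 log units; beyond the scatter).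

Compound 4 `C[C@@H](NC(=O)C1(NC(=O)c2cncc(Br)c2)CC1)c1ccc(-n2nc(Cl)c3ccccc32)cc1F` has not been measured. Its difference from compound 1 is 5-bromopyridin-3-yl in place of 2-methoxy-1,3-thiazol-5-yl on a carbonyl carbon. For the measured compounds named here, the step that bears most directly on it is the one to compound 2, whose 5-chloropyridin-3-yl differs from the 5-bromopyridin-3-yl of compound 4 only in the halogen, and that step, a 1.4-fold lower number from compound 1 to compound 2 (0.14 log units; within the scatter), stayed within the scatter. The step to compound 3 shows that a different substituent on the pyridine can bring a modest drop, but nothing measured suggests a bromo group would act like the methoxy group. Compound 4 is therefore expected to land close to compound 2, with a 1.4-fold lower number from compound 1 to compound 4 (0.14 log units; within the scatter) as the expected step, lying within the scatter. The estimate for compound 4 in this assay is 6 h, with a range of 3 h to 11 h.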

Compound 4, half-life: 7.6 h
Estimate against measurement, compound 4: 1.3-fold (0.10 log units) below; low and high end bracket the measured number.
By their numbers in this assay, from the lowest: compound 3; then compounds 2, 4 and 1 (each within the scatter of the next).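

In this assay, the 5-bromopyridin-3-yl on the carbonyl carbon takes the place of the 2-methoxy-1,3-thiazol-5-yl with no change that can be told from the scatter (a 1.1-fold lower number from compound 1 to compound 4 (0.04 log units; within the scatter)), so a second halogen-bearing pyridine now matches the thiazole of compound 1. Exchanging one halogen for the other also leaves the read-out unresolved (a 1.3-fold higher number from compound 2 to compound 4 (0.10 log units; within the scatter)), whereas bromo stands clearly apart from methoxy on the same pyridine (a 3.3-fold higher number from compound 3 to compound 4 (0.52 log units; beyond the scatter)), which repeats the separation already seen with chloro and leaves compound 3 as the only one of the four set apart from the others. No measurement among these compounds accounts for this separation of the methoxy compound.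

The compounds shown leave open whether a fluoro, methyl or amino group on the same pyridine would group with the halogens or with methoxy in this assay. For the compounds shown here, they also leave open whether a carboxylic acid or a longer alkoxy chain in that place would shift the half-life further, since the halogen comparison rests on only two members, chloro and bromo.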